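The compounds below may be only part of what the source reports. "The series", "measured", "known", "first", "only" and "open" are said of these compounds alone.

Of the compounds shown here, two from this series have been measured so far. Compound 1 `COc1ccc(NC(=O)CN2CCN(S(=O)(=O)c3ccc(F)cc3)CC2)cc1` and compound 2 `O=C(CN1CCN(S(=O)(=O)c2ccccc2F)CC1)Nc1ccc(F)cc1` share a common core and differ from each other in more than one place, so no single change can be read off between them. In an in vitro assay on HEK ts201 cells for negative allosteric modulation of Neuronal acetylcholine receptor; alpha4/beta2 (Homo sapiens), read by fluorescence and calcium flux, with a stated time of 1.5 s (on this read-out higher numbers stand for weaker inhibition and lower numbers for stronger inhibition), compound 1 gives 21100 nM, and in this assay compound 2 gives 8000 nM. Compound 2 therefore stands at the lower of the two numbers, and the gap to compound 1 is beyond the usual scatter of the measurement.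

The next compound, compound 3 `COc1ccc(NC(=O)CN2CCN(S(=O)(=O)c3ccccc3F)CC2)cc1`, is reached from compound 2 by one change: methoxy in place of fluoro on an aromatic carbon. Going by these compounds, the same exchange also sets compound 1 apart from compound 2, but alongside a second difference, so its effect on its own remains unknown. Compound 3 is expected to come out somewhat weaker than compound 2, that is, the step of a 1.8-fold higher number from compound 2 to compound 3 (0.24 log units; within the scatter) is estimated to be a modest rise in this assay, not far beyond the scatter. The value of compound 3 in this assay is therefore estimated at about 14000 nM, with a likely range from 6000 nM to 35000 nM.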

Compound 3, half-maximal inhibitory concentration: 17100 nM
Compound 3: the middle estimate sits 1.2-fold (0.09 log units) below what was measured; the measured number falls inside the stated range.
By their numbers in this assay, from the lowest: compound 2; then compounds 3 and 1 (each within the scatter of the next).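

Going by these compounds alone, with compound 3, the exchange of fluoro for methoxy on an aromatic carbon para to a large group can be read on its own for the first time: in this assay it gives a 2.1-fold higher number from compound 2 to compound 3 (0.33 log units; beyond the scatter), a modest step that lies only just beyond the scatter, so this position tolerates the larger methoxy with a limited loss of inhibition. Compound 3 also links the other two compounds on the sulfonyl side, where 2-fluorophenyl in place of 4-fluorophenyl on the sulfonyl sulfur gives a 1.2-fold lower number from compound 1 to compound 3 (0.09 log units; within the scatter), a step within the scatter, so these two fluorophenyl groups cannot be told apart in this measurement. Nothing measured here accounts for either step.

The compounds shown leave open whether the exchange of fluoro for methoxy would give a step of similar size with 4-fluorophenyl on the sulfonyl sulfur. They also leave open how other groups on the same aromatic carbon, such as chlorine, a nitrile or an amine, would compare with fluoro and methoxy.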